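This account rests on a few compounds, and the source may have more. Where it says the series, first, only, none or still open, it means among the compounds named here.

Working notes on a small set of amides built on a shared core, all tested in a functional assay on KYSE-70 cells for antiproliferative activity against KYSE-70 cell line (Homo sapiens), read by MTT assay, with a stated time of 72 h; a higher number here means a weaker inhibitor, a lower number a stronger inhibitor. Compound 1 is `COc1ccc(NC(=O)c2cc(=O)[nH]c3cc(Br)ccc23)cc1`. In this assay compound 1 reaches only the limit, > 20000 nM, and not a number. Compound 2 is `O=C(Nc1cc(F)cc(F)c1)c1cc(=O)[nH]c2cc(F)ccc12`. Compound 2 likewise sits at the limit in this assay, > 20000 nM. Compound 3 is `CC(C)(C)c1ccc(-c2ccc3c(C(=O)Nc4cccc(F)c4)cc(=O)[nH]c3c2)cc1`. For compound 3 this assay again returns a limit, > 20000 nM. Among the measured compounds shown here, compound 3 thus stands nowhere distinct within the set: the limit of > 20000 nM in this assay, at which 3 of the 3 values shown sit, so no compound can be ranked against another and no measured step exists here.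

Compound 4 is `O=C(Nc1cccc(F)c1)c1cc(=O)[nH]c2cc(-c3cccnc3F)ccc12`. It differs from compound 3 in a single place: 2-fluoropyridin-3-yl in place of 4-(tert-butyl)phenyl on an aromatic carbon. For the measured compounds named here, with every measured member of the set at the limit, no step of any size or direction has been observed, and the numbers give no ground for expecting this change to move the read-out. The expected step is a number no higher from compound 3 to compound 4 (the limit leaves the size open), that is, none beyond the scatter. Compound 4 is estimated at 20000 nM in this assay, with a range from 5000 nM to 80000 nM, and the most likely outcome is that this assay again reports only a limit for compound 4.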

Compound 4, half-maximal inhibitory concentration: > 20000 nM
Compound 4 was reported as a limit; the forecaster's own chance of this, stated with the estimate: 75%; the middle value sits exactly at the limit.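

Compound 3 and compound 4 both stand at a limit and not at a number in this assay, so no step between them can be read: the limit of > 20000 nM in this assay, at which 4 of the 4 values shown sit.

Left open is whether 2-fluoropyridin-3-yl in place of 4-(tert-butyl)phenyl changes the read-out at all, and whether any amide on the shared core gives a measurable value.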